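The source may hold more compounds than are shown below. What is called first, only, known or untested is meant among the compounds shown, and "the series" means these compounds.

For the measured compounds named here, in an ADME assay on A549 cells (Homo sapiens) for cytotoxicity, read by resazurin assay, with a stated time of 48 h (a higher number here means that more compound is tolerated, a lower number that less compound is tolerated), three compounds with a shared core have numbers so far. Compound 1 (`CCNc1ccc(NC(=O)c2cc(Cl)ccc2O)c(Cl)c1`) gives 30200 nM, compound 2 (`O=C(Nc1ccc(NCc2ccccc2)cc1Cl)c1cc(Cl)ccc1O`) gives 19700 nM, and compound 3 (`COc1ccc(CNc2ccc(NC(=O)c3cc(Cl)ccc3O)c(Cl)c2)cc1`) gives 80700 nM, the highest of the three. Compound 4 (`O=C(Nc1ccc(NCc2ccc(O)cc2)cc1Cl)c1cc(Cl)ccc1O`) has not yet been measured. It differs from compound 3 by hydrogen in place of methyl on an oxygen on an aromatic ring, so 4-methoxybenzyl becomes 4-hydroxybenzyl.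

The nearest guide is a 4.1-fold higher number from compound 2 to compound 3 (0.61 log units; beyond the scatter), with methoxy in place of hydrogen on an aromatic carbon. The other two steps, a 1.5-fold lower number from compound 1 to compound 2 (0.19 log units; within the scatter) and a 2.7-fold higher number from compound 1 to compound 3 (0.43 log units; beyond the scatter), show how far the number has moved when the group on that chain carbon changed. Going by the values given here, no measured compound carries a hydroxy group, so these steps are only a partial guide. A modest drop that undoes part of the methoxy gain is expected in this assay, an estimated 2.2-fold lower number from compound 3 to compound 4 (0.35 log units; beyond the scatter). For compound 4 the estimate is 36000 nM, with an expected range of 14000 nM to 90000 nM.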

Compound 4, half-maximal cytotoxic concentration: 116000 nM
The estimate for compound 4 lay 3.2-fold (0.51 log units) below the measured number, outside the stated range (above it).
By their numbers in this assay, from the lowest: compounds 2 and 1 (each within the scatter of the next); then compounds 3 and 4 (each within the scatter of the next).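

In this assay, hydrogen in place of methyl on the oxygen gives a 1.4-fold higher number from compound 3 to compound 4 (0.16 log units; within the scatter), so at this position the methoxy and hydroxy compounds cannot be told apart, and the methyl is not needed for the distance from the other two compounds. The hydroxy group on that aromatic carbon gives a 5.9-fold higher number from compound 2 to compound 4 (0.77 log units; beyond the scatter), and 4-hydroxyphenyl in place of the methyl on the chain carbon gives a 3.8-fold higher number from compound 1 to compound 4 (0.58 log units; beyond the scatter), so a second oxygen-linked group now stands beyond the scatter from both compound 1 and compound 2. The compounds shown carry no evidence that explains this.

As far as these compounds go, whether an amine or a carboxylic acid on that aromatic carbon would keep the number in the same range remains open. So does the outcome for a longer chain on the oxygen, such as ethoxy.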